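A few compounds are considered here, and "the series" means these few. Any claim that something is new, unique, unknown or untested is made for them only; others in the source may bear on it.

Measured compounds:
Compound 1 `CN(CCC#N)C[C@H]1CN(c2ccc(-n3cc(-c4ccccn4)cn3)c(F)c2)C(=O)O1` gives 1.9.
Compound 2 `O=C1O[C@@H](CN2CCC(c3ccc(F)cc3)CC2)CN1c1ccc(-n2cc(-c3ccccn3)cn2)c(F)c1` gives 5.78.
Compound 3 `CC(=O)OC[C@H]1CN(c2ccc(-n3cc(-c4ccccn4)cn3)c(F)c2)C(=O)O1` gives 2.09.

In a physicochemical assay for lipophilicity, read by HPLC, measured as octanol-water partition (on this read-out higher numbers stand for higher lipophilicity and lower numbers for lower lipophilicity), compound 3 stands second highest of the three numbers. Its nearest neighbour is compound 1, whose value sits within the scatter of that of compound 3; the furthest is compound 2, whose 5.78 lies far beyond the scatter above.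

Compound 4 `CCNC(=O)NC[C@H]1CN(c2ccc(-n3cc(-c4ccccn4)cn3)c(F)c2)C(=O)O1` has not yet been measured in this assay. It differs from compound 3 as follows: (ethylcarbamoyl)amino in place of acetoxy on a saturated chain carbon bound to a saturated ring carbon.

Among the measured compounds shown here, only one measured step bears on this change, the one at the same place: a number 0.19 log units higher from compound 1 to compound 3 (within the scatter), which stayed within the scatter. For the measured compounds named here, no measured step exchanges an acetoxy for an (ethylcarbamoyl)amino, so the expectation rests on compound 3 alone. A modest step down in this assay is expected for compound 4, estimated as a number 0.59 log units lower from compound 3 to compound 4 (beyond the scatter). Compound 4 is therefore expected to give about 1.5, with a range from 1 to 2.1.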

Compound 4, partition coefficient: 2.45
Estimate against measurement, compound 4: 0.95 log units below; the whole stated range lies below it.
By their numbers in this assay, from the lowest: compounds 1 and 3 (each within the scatter of the next); then compound 4; then compound 2.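

In this assay, this position now shows changes beyond the scatter, which the earlier step at the same place did not: the exchange of acetoxy for (ethylcarbamoyl)amino gives a number 0.36 log units higher from compound 3 to compound 4 (beyond the scatter) and the exchange of (2-cyanoethyl)(methyl)amino for the same group gives a number 0.55 log units higher from compound 1 to compound 4 (beyond the scatter) on the same saturated chain carbon. Among the compounds shown here, both steps are modest and point the same way, and the first brings in a group of 6 heavy atoms and 2 hydrogen-bond donors in place of one of 4 heavy atoms and 0 hydrogen-bond donors. Nothing measured here accounts for the rise.

The compounds shown leave open whether the ethyl chain carries this step, as a propyl or a methyl on the same group would show. They also leave open where a primary amine or a carboxylic acid at this chain carbon would stand.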